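Swapping the Amide Substituent: From Compound 2 to Compound 4

A few compounds are considered here, and "the series" means these few. Any claim that something is new, unique, unknown or untested is made for them only; others in the source may bear on it.

Three compounds have been measured in a functional assay on MDA-MB-231 cells (Homo sapiens) for inhibition, read by MTT assay; on this read-out lower numbers stand for stronger inhibition of growth and higher numbers for weaker inhibition of growth:
Compound 1 `CC1=C(/C=C/C(C)=C/C=C/C(C)=C\C(=O)Nc2ccccc2)C(C)(C)CC=C1c1cccnc1`: 25100 nM
Compound 2 `CC1=C(/C=C/C(C)=C/C=C/C(C)=C\C(=O)NCc2ccc(O)cc2)C(C)(C)CCC1n1ccnc1`: 2230 nM
Compound 3 `CC1=C(/C=C/C(C)=C/C=C/C(C)=C\C(=O)Nc2ccccc2)C(C)(C)CCC1n1ccnc1`: 1740 nM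

Among these three, compound 2 stands second highest. Compound 3 lies within the usual scatter of it, while compound 1 sits clearly higher, well beyond the scatter.

Compound 4 `CC1=C(/C=C/C(C)=C/C=C/C(C)=C\C(=O)Nc2ccccc2O)C(C)(C)CCC1n1ccnc1` has not yet been measured. Its difference from compound 2 is 2-hydroxyphenyl in place of 4-hydroxybenzyl on an amide-type nitrogen.

Within the data shown here, one measured step bears on this change: a 1.3-fold lower number from compound 2 to compound 3 (0.11 log units; within the scatter), where phenyl replaced 4-hydroxybenzyl on the same amide-type nitrogen. Compound 4 carries a 2-hydroxyphenyl there, so it resembles compound 3 more closely than compound 2 does. No step beyond the scatter is therefore expected in this assay ; the estimated step is a 1.2-fold lower number from compound 2 to compound 4 (0.07 log units; within the scatter).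

Compound 4 is estimated to give 1900 nM, between 700 nM and 5000 nM.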

Compound 4, concentration for 50% growth inhibition: 4670 nM
For compound 4 the middle estimate is 2.5-fold (0.39 log units) below the measured one; measured number inside the range.
By their numbers in this assay, from the lowest: compounds 3 and 2 (each within the scatter of the next); then compound 4; then compound 1.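

In this assay, among these compounds, this position on the amide-type nitrogen proves sensitive to a change that the earlier compounds did not reveal: 2-hydroxyphenyl in place of 4-hydroxybenzyl gives a 2.1-fold higher number from compound 2 to compound 4 (0.32 log units; beyond the scatter). Adding only a hydroxy to the phenyl gives a 2.7-fold higher number from compound 3 to compound 4 (0.43 log units; beyond the scatter), so in this pair that single hydroxy is enough to weaken growth inhibition beyond the scatter. Nothing available explains this difference. On these data alone, whether a methoxy or an amine in place of that hydroxy would give a number nearer compound 3 or compound 4 stays open.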